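Replacing 4-Fluorophenyl with Ethoxy on a Carbonyl Carbon

The source may hold more compounds than are shown below. What is called first, only, known or untested is meant among the compounds shown, and "the series" means these compounds.

In a functional assay on HT-29 cells (Homo sapiens) for inhibition, read by MTT assay, with a stated time of 48 h (a higher number here means a weaker inhibitor, a lower number a stronger inhibitor), compound 1 (`COc1ccc(C(=O)CSc2nnc(-c3cc(OC)c(OC)c(OC)c3)n2-c2ccc(OC)cc2)cc1`) gives > 60000 nM, which is a limit of the assay. Going by the values given here, compound 2 (`COc1ccc(-n2c(SCC(=O)c3ccc(F)cc3)nnc2-c2cc(OC)c(OC)c(OC)c2)cc1`) gives 42500 nM, the only exact number so far. Compound 3 (`CCOC(=O)CSc1nnc(-c2cc(OC)c(OC)c(OC)c2)n1-c1ccc(OC)cc1`) carries ethoxy in place of 4-fluorophenyl on a carbonyl carbon. Among the compounds with values here, the only measured step, an at least 1.4-fold lower number from compound 1 to compound 2 (0.14 log units; that floor lies within the scatter), puts fluoro in place of methoxy on an aromatic carbon and bears only loosely on this swap, so no change beyond the scatter is expected in this assay. The estimated change is a 1.1-fold higher number from compound 2 to compound 3 (0.02 log units; within the scatter). Compound 3 is expected at 45000 nM, within a range of 20000 nM to 60000 nM.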

Compound 3, half-maximal inhibitory concentration: > 60000 nM
Compound 3: a limit, no number (the forecaster's own chance of this, stated with the estimate: 40%); middle value at least 1.3-fold (0.12 log units) away from the limit.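

Putting ethoxy in place of 4-fluorophenyl on the carbonyl carbon gives an at least 1.4-fold higher number from compound 2 to compound 3 (0.14 log units; that floor lies within the scatter) in this assay. Compound 3 gives a limit, not a number, so a group with no ring at this position yields no measurable value, and the step between compound 1 and compound 3 cannot be read. What can be said about this position is capped by a single feature of the data: the limit of > 60000 nM in this assay, at which 2 of the 3 values shown sit.

Going by these compounds, whether an amine or a carboxylic acid on this carbonyl carbon would give an exact number stays open. So does the effect of a longer chain in place of ethoxy.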